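Shifting a fluorine around the ring in a Vero cytotoxicity series

The source may hold more compounds than are shown below. What is called first, only, known or untested is meant among the compounds shown, and "the series" means these compounds.

Measured compounds:
compound 1, `Cc1ccc(C2SCC(=O)N2CCN2CCCCC2)cc1`: 17%
compound 2, `O=C1CSC(c2ccc(F)cc2)N1CCN1CCCCC1`: 17%

In an ADME assay on Vero cells (Chlorocebus sabaeus) for cytotoxicity, read by neutral red uptake, tested at 787 ug/mL (a higher number here means a weaker effect of the compound at the concentration tested, a lower number a stronger effect), compound 1 gives 17%. Compound 2, with fluoro in place of methyl on an aromatic carbon, gives 17%, so the step of no change at the digits printed from compound 1 to compound 2 (within the scatter) leaves compound 2 level with compound 1 within the scatter.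

Compound 3, `O=C1CSC(c2cccc(F)c2)N1CCN1CCCCC1`, has not yet been measured in this assay. It differs from compound 2 by 3-fluorophenyl in place of 4-fluorophenyl on a saturated ring carbon. Within the data shown here, the only measured step, from compound 1 to compound 2, concerns the aromatic substituent and showed no change beyond the scatter; no measured step covers a shift of the fluorine around the aromatic ring. On that slim basis the step of no change at the digits printed from compound 2 to compound 3 (within the scatter) is expected to be none beyond the scatter. Compound 3 is therefore estimated at 17% in this assay, within a range from 7% to 28%.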

Compound 3, a percentage reported as activity, at one concentration (the size of the read-out at that concentration, not a potency): 27%
Beside the measured number, compound 3's estimate is 10 percentage points below it; the measured number falls inside the stated range.
By their numbers in this assay, from the lowest: compounds 1, 2 and 3 (each within the scatter of the next).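

In this assay, among these compounds, moving the fluorine from 4-fluorophenyl to 3-fluorophenyl on the saturated ring carbon gives a number 10 percentage points higher from compound 2 to compound 3 (within the scatter), which is the first reading of where the fluorine sits on this aromatic ring. Exchanging 4-methylphenyl for 3-fluorophenyl at the same place gives a number 10 percentage points higher from compound 1 to compound 3 (within the scatter), so across these three compounds neither the kind of substituent nor the shift of the fluorine leaves the scatter. Nothing available explains the numbers of these compounds.

On these data alone, what remains open is whether a different group on the aromatic ring, such as trifluoromethyl, a nitrile or a carboxylic acid in place of the fluorine, would give a step beyond the scatter. The compounds shown also leave open what a change away from this ring would do, for example a longer chain in place of the two-carbon link on the ring nitrogen.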